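Shortening the amide linker on the butyl-substituted analogue

The source may hold more compounds than are shown below. What is called first, only, known or untested is meant among the compounds shown, and "the series" means these compounds.

Of the compounds shown here, two have been measured in a functional assay on NCI-H460 cells (Homo sapiens) for antiproliferative activity, read by CCK-8 assay, with a stated time of 72 h, tested at 8 uM; on this read-out lower numbers stand for a weaker effect and higher numbers for a stronger effect at the one concentration tested. Compound 1 `CC(C)n1cnc2c(Nc3ccccc3)nc(NCOCc3ccc(C(=O)Nc4ccccc4N)cc3)nc21` gives 34.3% in this assay. Compound 2 `CCCCn1cnc2c(Nc3ccccc3)nc(NCOCc3ccc(/C=C/C(=O)Nc4ccccc4N)cc3)nc21` gives 34.2% in this assay. Compound 2 thus stands beside compound 1: the two values lie within the scatter of each other, and neither can be placed above the other. Among the compounds with values here, since compounds 1 and 2 differ in two places, no single step between them is given.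

Compound 3 `CCCCn1cnc2c(Nc3ccccc3)nc(NCOCc3ccc(C(=O)Nc4ccccc4N)cc3)nc21` has not been measured. It differs from compound 2 in one place: (2-aminophenyl)carbamoyl in place of 2-((2-aminophenyl)carbamoyl)ethenyl on an aromatic carbon. Within the data shown here, the entering group is the one already present in compound 1, which gives 34.3% in this assay, a value within the scatter of compound 2. Among the measured compounds shown here, the only evidence at hand is therefore that the two amide groups, each paired with a different substituent on the shared core, give indistinguishable values. No step beyond the scatter is expected for a number 0.2 percentage points lower from compound 2 to compound 3 (within the scatter). For compound 3 an inhibition of 34% is estimated, with a range from 22% to 46%.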

Compound 3, a percentage reported as inhibition, at one concentration (the size of the read-out at that concentration, not a potency): 51.3%
Compound 3: the middle estimate sits 17.3 percentage points below what was measured; measured number above the stated range.
By their numbers in this assay, from the lowest: compounds 2 and 1 (each within the scatter of the next); then compound 3.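

In this assay, the (2-aminophenyl)carbamoyl group in place of 2-((2-aminophenyl)carbamoyl)ethenyl on the aromatic carbon gives a number 17.1 percentage points higher from compound 2 to compound 3 (beyond the scatter), so with butyl on the aromatic nitrogen this position responds to the change, something compounds 1 and 2 could not show while they differed in two places. With the (2-aminophenyl)carbamoyl group held, butyl in place of isopropyl on that aromatic nitrogen gives a number 17 percentage points higher from compound 1 to compound 3 (beyond the scatter), so the agreement of compound 1 and compound 2 within the scatter does not mean that either place is without influence: each lies one change from compound 3, and both changes count here. No measurement at hand bears on what lies behind either step.

Open, going by these compounds, is whether a longer chain such as hexyl on the aromatic nitrogen, or a saturated ethyl link in place of the ethenyl, would move the number further, and whether the ethenyl step has the same size with isopropyl on the nitrogen. All of these numbers describe the effect at one concentration, so they show only a stronger or weaker effect at that concentration.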